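The source may report more compounds than this note shows. Statements on the series, on what has been measured and on what is new or still open speak of the compounds shown alone.

In a functional assay on A549 cells (Homo sapiens) for inhibition, read by colorimetric assay and MTT assay, with a stated time of 72 h (on this read-out lower numbers stand for stronger inhibition and higher numbers for weaker inhibition), compound 3 `C=CCCCCOc1ncc(-c2ccccc2OC)n1C` gives 5000 nM and so lies within the scatter of compound 1 `C=CCCCCOc1ccccc1-c1cnc(OCCCCC=C)n1C` at 7000 nM on this read-out. Compound 2 `COc1ccccc1-c1cnc(OC)n1C` reads > 100000 nM as a limit of the assay and not as a number. Two measured steps frame the series: an at least 20-fold lower number from compound 2 to compound 3 (1.30 log units; beyond the scatter) is large, and a 1.4-fold lower number from compound 1 to compound 3 (0.15 log units; within the scatter) stays within the scatter. Both concern the chain on oxygen, and neither touches the aromatic ring now changed. Going to compound 4 `C=CCCCCOc1ncc(-c2cc(C(C)C)ccc2OC)n1C` the change is isopropyl in place of hydrogen on an aromatic carbon with isopropyl in place of hydrogen on an aromatic carbon, para to a methoxy group. Within the data shown here, no measured step sits at this place, so the expected size in this assay rests on little evidence. No step beyond the scatter is firmly expected, with a slight lean toward a lower number. The expected step is a 1.3-fold lower number from compound 3 to compound 4 (0.10 log units; within the scatter) on present evidence. For compound 4 the estimated value is 4000 nM within an expected range of 1300 nM to 13000 nM on this read-out.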

Compound 4, half-maximal inhibitory concentration: 4000 nM
Estimate against measurement, compound 4: no gap at the digits printed, within the range that was stated.
By their numbers in this assay, from the lowest: compounds 4, 3 and 1 (each within the scatter of the next). At a limit, above all of these: compound 2.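

In this assay, isopropyl in place of hydrogen on an aromatic carbon, para to a methoxy group, gives a 1.3-fold lower number from compound 3 to compound 4 (0.10 log units; within the scatter). The earlier steps shown here concern only the chain on oxygen, so this is the one measured view of this position, and it shows that a branched group of 3 carbon atoms can sit here with no step beyond the scatter. Nothing measured here accounts for the size of this step.

A single group at a single position leaves open whether the same carbon tolerates other kinds of group, such as an amine, a carboxylic acid or a longer chain. Also open, going by these compounds, is whether isopropyl at this place would give a similar step on the core of compound 1 or compound 2.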